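This account rests on a few compounds, and the source may have more. Where it says the series, first, only, none or still open, it means among the compounds named here.

In a functional assay on HL-60 cells (Homo sapiens) for cytotoxicity, read by MTT assay, with a stated time of 46 h (a lower number here means a stronger inhibitor, a higher number a weaker inhibitor), compound 1 `O=C1/C(=C\c2ccccc2)C(c2ccccc2)Oc2ccccc21` gives 27300 nM. Compound 2 `O=C1/C(=C\c2ccc(Br)cc2)C(c2ccccc2)Oc2ccccc21` gives > 1000000 nM, which is a limit of the assay and not a number. Going by the values given here, compound 3 `O=C1/C(=C\c2ccc(O)cc2)COc2ccccc21` gives 6500 nM, the lowest number so far and lower than the value of compound 1 by more than the scatter. Compound 4 `O=C1/C(=C/c2ccc(O)cc2)COc2ccccc21` differs from compound 3 only in configuration: the two compounds have the same atoms and bonds and differ only in configuration as drawn: 1 of 1 stereo elements differ; a double bond is drawn Z in compound 3 and E in compound 4; a double bond is drawn Z in compound 3 and E in compound 4. Among the compounds with values here, the only measured step is an at least 36-fold higher number from compound 1 to compound 2 (1.56 log units; beyond the scatter), a large step from bromo in place of hydrogen on an aromatic carbon. It shows that one change can move the number far, but no configuration change has been measured, so it gives no direction. The expected step, a 1.2-fold higher number from compound 3 to compound 4 (0.09 log units; within the scatter), is therefore none beyond the scatter, with a wide margin on either side. For compound 4 the estimated value is 8000 nM, with an expected range of 2000 nM to 30000 nM.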

Compound 4, half-maximal inhibitory concentration in the HL-60 assay: 5700 nM
For compound 4 the middle estimate is 1.4-fold (0.15 log units) above the measured one, and the stated range covers the measured number.
By their numbers in the HL-60 assay, from the lowest: compounds 4 and 3 (each within the scatter of the next); then compound 1. At a limit, above all of these: compound 2.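

Going by these compounds alone, in the HL-60 assay compound 3 gives 6500 nM and compound 4 gives 5700 nM, and the change of the double bond from Z to E as drawn gives a 1.1-fold lower number from compound 3 to compound 4 (0.06 log units; within the scatter), so configuration alone does not move the number beyond the scatter at this position, unlike the bromo step among the earlier compounds. In a physicochemical assay for lipophilicity, read by HPLC (on this read-out higher numbers stand for higher lipophilicity and lower numbers for lower lipophilicity), compound 3 gives 2.92 and compound 4 gives 3.1, and the same change gives a number 0.18 log units higher from compound 3 to compound 4 (within the scatter), so the pair is not separated on this read-out either.

On these data alone, whether configuration is equally without effect on compounds carrying the additional phenyl group of compounds 1 and 2 remains open. So does the outcome of an amine or a carboxylic acid in place of the hydroxyl group of compounds 3 and 4.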